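This account rests on a few compounds, and the source may have more. Where it says the series, first, only, none or still open, it means among the compounds named here.

Of the compounds shown here, three have so far been tested in an ADME assay on MRC5 cells (Homo sapiens) for inhibition, with a stated time of 72 h; on this read-out higher numbers stand for an effect only at larger amounts of compound and lower numbers for an effect already at smaller amounts. Compound 1 `COc1cccc(OC)c1C(=O)Nc1c[nH]nc1C(=O)NC1CCCCCC1` gives 42000 nM in this assay, the highest of the three numbers, though the next compound sits within the scatter of it. Compound 2 `CO[C@H]1CC[C@H](NC(=O)c2n[nH]cc2NC(=O)c2ncoc2-c2ccccc2)CC1` gives 28000 nM, a number that cannot be told apart from that of compound 1. Compound 3 `CO[C@H]1CC[C@H](NC(=O)c2n[nH]cc2NC(=O)c2ccccc2C(F)(F)F)CC1` gives 3300 nM, and the gap from compound 3 to compound 1 lies beyond the scatter, so compound 1 shows its effect only at larger amounts than compound 3. For the measured compounds named here, no pair of these three compounds differs in a single place, so no single step between measured compounds can be read off.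

Compound 4 `COc1cccc(OC)c1C(=O)Nc1c[nH]nc1C(=O)NCCCN(C)C` has not yet been measured. It differs from compound 1 in one place: 3-(dimethylamino)propyl in place of cycloheptyl on an amide-type nitrogen. Going by the values given here, nothing among the measured compounds shows what a change of this kind does in this assay, so a step of no more than the scatter is expected, without a firm direction. Compound 4 is expected to give about 50000 nM in this assay, with a range from 20000 nM to 110000 nM. The expected step, a 1.2-fold higher number from compound 1 to compound 4 (0.08 log units; within the scatter), would mean no change beyond the scatter.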

Compound 4, half-maximal effective concentration: > 50000 nM
Compound 4 was reported as a limit; the forecaster's own chance of this, stated with the estimate: 30%; the middle value sits exactly at the limit.
By their numbers in this assay, from the lowest: compound 3; then compounds 2 and 1 (each within the scatter of the next). At a limit, above all of these: compound 4.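

In this assay compound 4 gives > 50000 nM, which is a limit of the assay and not a number. For the compounds shown here, replacing cycloheptyl with 3-(dimethylamino)propyl on the amide-type nitrogen provides the first single-place step in this set, and it reads as an at least 1.1-fold higher number from compound 1 to compound 4 (0.07 log units; that floor lies within the scatter), a floor that lies within the scatter. Replacing this ring with an open chain containing a nitrogen therefore did not bring the effect down to smaller amounts of compound, but how far compound 4 really lies from compound 1 cannot be read.

On these data alone, it remains open how a smaller ring such as cyclopentyl, a shorter chain ending in an amine, or a chain ending in a carboxylic acid would behave at this place. As far as these compounds go, it is also open whether any group here could move the number beyond the scatter.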